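Lengthening the Chain and Swapping Hydroxyethyl for Methyl

The compounds below may be only part of what the source reports. "The series", "measured", "known", "first", "only" and "open" are said of these compounds alone.

Three measured compounds share one core and differ only in the chain and the saturated ring at its end. Compound 1 `COc1ccc(-c2cc(=O)c3ccc(OCCCCN4CCC(CCO)CC4)cc3o2)cc1` gives 38400 nM in a functional assay for inhibition, read by fluorescence and spectrophotometry, with a stated time of 30 h; a lower number here means a stronger inhibitor, a higher number a weaker inhibitor. Compound 2 `COc1ccc(-c2cc(=O)c3ccc(OCCCCCN4CCC(C)CC4)cc3o2)cc1` gives 55100 nM in this assay, and compound 3 `COc1ccc(-c2cc(=O)c3ccc(OCCCCCCN4CCC(CCO)CC4)cc3o2)cc1` gives 50400 nM in this assay. Compound 2 differs from compound 1 by (4-methylpiperidin-1-yl)methyl in place of 4-(2-hydroxyethyl)piperidin-1-yl on a saturated chain carbon, four bonds along the chain from an oxygen on an aromatic ring, a step of a 1.4-fold higher number from compound 1 to compound 2 (0.16 log units; within the scatter). Compound 3 differs from compound 1 by a group of 11 heavy atoms (9 carbon, 1 nitrogen, 1 oxygen; one six-membered non-aromatic ring with 1 hetero atom) in place of a group of 9 heavy atoms (7 carbon, 1 nitrogen, 1 oxygen; one six-membered non-aromatic ring with 1 hetero atom), on a saturated chain carbon, four bonds along the chain from an oxygen on an aromatic ring, a step of a 1.3-fold higher number from compound 1 to compound 3 (0.12 log units; within the scatter). Compound 4 `COc1ccc(-c2cc(=O)c3ccc(OCCCCCCCN4CCC(C)CC4)cc3o2)cc1` has not yet been measured; it differs from compound 3 by (4-methylpiperidin-1-yl)methyl in place of 4-(2-hydroxyethyl)piperidin-1-yl on a saturated chain carbon, six bonds along the chain from an oxygen on an aromatic ring. This is the same kind of change as from compound 1 to compound 2, but the place differs: there the change sits four bonds along the chain from an oxygen on an aromatic ring, here it sits six bonds along the chain from an oxygen on an aromatic ring. A similarly small step is expected from compound 3 to compound 4, a 1.3-fold higher number from compound 3 to compound 4 (0.11 log units; within the scatter), resting on the earlier step of a 1.4-fold higher number from compound 1 to compound 2 (0.16 log units; within the scatter). Compound 4 is therefore expected to give about 65000 nM in this assay, most likely between 30000 nM and 140000 nM.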

Compound 4, half-maximal inhibitory concentration: 61600 nM
The estimate for compound 4 lay 1.1-fold (0.02 log units) above the measured number; measured number inside the range.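

Putting (4-methylpiperidin-1-yl)methyl in place of 4-(2-hydroxyethyl)piperidin-1-yl gave a 1.2-fold higher number from compound 3 to compound 4 (0.09 log units; within the scatter) in this assay, a small step that matches the earlier one: the same change on two cores in this assay, a 1.4-fold higher number (0.16 log units; within the scatter) from compound 1 to compound 2 and a 1.2-fold higher number (0.09 log units; within the scatter) from compound 3 to compound 4, 1.2-fold (0.07 log units) apart, within the scatter of two such steps. In these two pairs, then, the change carries from one core to the other without a detectable difference, and the remaining new steps, a 1.1-fold higher number from compound 2 to compound 4 (0.05 log units; within the scatter) and a 1.6-fold higher number from compound 1 to compound 4 (0.21 log units; within the scatter), also stay within the scatter. Going by these compounds alone, this does not show that the change would behave alike on every core, nor that it has no effect at all: only two pairs can be compared, and steps this small cannot separate a real effect from the scatter.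

The compounds shown leave open whether any change at the end of the chain can move the number beyond the scatter, for example a morpholine in place of the piperidine or a carboxylic acid in place of the hydroxyl. They also leave open how the same swap behaves on a shorter chain.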